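Cyano in place of hydrogen on the benzyloxy ring

The compounds below may be only part of what the source reports. "The series", "measured", "known", "first", "only" and "open" are said of these compounds alone.

Measured so far:
compound 1 `FC(F)(F)c1ccc(CN2CCN(Cc3cc(-c4ccc(OCc5ccccc5)cc4)on3)CC2)cc1` gives 2900 nM
compound 2 `FC(F)(F)c1ccc(CN2CCN(Cc3cc(-c4ccc(OCc5ccccc5Cl)cc4)on3)CC2)cc1` gives 2800 nM
compound 3 `N#Cc1ccccc1COc1ccc(-c2cc(CN3CCN(Cc4ccc(C(F)(F)F)cc4)CC3)no2)cc1` gives 4000 nM

All three were tested in a functional assay on MCF7 cells (Homo sapiens) for antiproliferative activity, read by sulforhodamine B assay, with a stated time of 72 h; a lower number here means a stronger inhibitor, a higher number a weaker inhibitor. Compound 1 stands second highest of the three numbers; compound 2 is nearest to it, and compound 3 is furthest, yet every gap among them lies within the scatter.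

The unmeasured compound 4 `N#Cc1ccc(COc2ccc(-c3cc(CN4CCN(Cc5ccc(C(F)(F)F)cc5)CC4)no3)cc2)cc1` differs from compound 1 in one place: cyano in place of hydrogen on an aromatic carbon. Among the compounds with values here, two measured steps bear on this. The step of a 1.4-fold higher number from compound 1 to compound 3 (0.14 log units; within the scatter) is the same kind of change, cyano in place of hydrogen on an aromatic carbon, though not on the same carbon of that ring. The step of a 1.0-fold lower number from compound 1 to compound 2 (0.02 log units; within the scatter) shows that another small substituent on that ring also left the number where it was. Neither step moved beyond the scatter, so no step beyond the scatter is expected for compound 4 either.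

Compound 4 is therefore estimated at 3500 nM, with a range from 1800 nM to 7000 nM; the expected step is a 1.2-fold higher number from compound 1 to compound 4 (0.08 log units; within the scatter).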

Compound 4, half-maximal inhibitory concentration: 100 nM
For compound 4 the middle estimate is 35-fold (1.54 log units) above the measured one; the whole stated range lies above it.
By their numbers in this assay, from the lowest: compound 4; then compounds 2, 1 and 3 (each within the scatter of the next).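

Within the data shown here, this carbon of the benzyloxy ring is far more sensitive than the earlier compounds suggested: they showed no step beyond the scatter, whereas the cyano group, para to a large group, gives a 29-fold lower number from compound 1 to compound 4 (1.46 log units; beyond the scatter) in a single change. Which carbon carries the cyano group clearly matters, since moving from 2-cyanophenyl to 4-cyanophenyl gives a 40-fold lower number from compound 3 to compound 4 (1.60 log units; beyond the scatter) and replacing 2-chlorophenyl with 4-cyanophenyl gives a 28-fold lower number from compound 2 to compound 4 (1.45 log units; beyond the scatter) on the same benzyloxy frame. Nothing measured here explains why this one placement stands apart.

Whether the effect belongs to the cyano group itself remains open, as other groups on this same carbon, such as a methoxy, an amine or a carboxylic acid, are absent from the compounds shown. From the compounds shown here alone, it is also open whether the step would persist with a methyl in place of the trifluoromethyl at the other end of the molecule.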